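A few compounds are considered here, and "the series" means these few. Any claim that something is new, unique, unknown or untested is made for them only; others in the source may bear on it.

The piece follows the shared core of compound 1, `O=C(Cn1cc(C(=O)O)nn1)NCc1ccccc1`, into compound 4, `COc1ccc(-c2cn(CC(=O)NCc3ccccc3)nn2)cc1`, on the toxicity read-out of an ADME assay on cells (spleen, Mus musculus, strain C57BL/6) for inhibition, read by flow cytometry and propidium iodide staining, with a stated time of 24 h, at 37 degrees C; a higher number here means that more compound is needed for the effect, a lower number that less compound is needed. Compound 1 stands without a single number on this read-out: in this assay compound 1 is recorded as "non-toxic" (no number reported). The same holds for compound 3, `O=C(Cn1cc(-c2ccccc2C(F)(F)F)nn1)NCc1ccccc1`, which in this assay is also recorded as "non-toxic" (no number reported). Only compound 2, `O=C(Cn1cc(C(=O)OCc2ccccc2)nn1)NCc1ccccc1`, carries a figure: in this assay compound 2 gives 720 uM, a concentration for half-maximal effect far up the range. With two of three entries lacking a number, compound 1 cannot be ranked against its neighbours.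

The change from compound 1 to compound 4 is 4-methoxyphenyl in place of carboxy on an aromatic carbon. For the measured compounds named here, no measured pair shows this change, so its size on this assay is not known. Since compound 3, which also carries an aryl group in place of the carboxy, is recorded as "non-toxic" (no number reported), and since even compound 2 reaches only 720 uM, the step from compound 1 to compound 4 is expected to stay within the scatter, or to leave compound 4 likewise without a number. For compound 4 in this assay a concentration for half-maximal effect of about 600 uM is estimated, with a range from 150 uM to 2500 uM.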

Compound 4, concentration for half-maximal effect: "non-toxic" (no number reported)
No number was reported for compound 4; no gap can be computed for the estimate.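

In this assay compound 4, like compound 1, carries no single number, so no new step can be read between compound 1 and compound 4. No supporting evidence bears on this result. The compounds shown leave open how large the change from carboxy to 4-methoxyphenyl is on this read-out, and how compound 1, compound 3 and compound 4 rank against compound 2.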